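From fluoro to nitro: estimating a cytotoxicity value

A few compounds are considered here, and "the series" means these few. Any claim that something is new, unique, unknown or untested is made for them only; others in the source may bear on it.

Compound 1 `O=C(CCN1CCN(c2ccc([N+](=O)[O-])cc2)CC1)c1ccc(Br)cc1` gives 79800 nM
Compound 2 `O=C(CCN1CCN(c2ccc(F)cc2)CC1)c1ccc(C(F)(F)F)cc1` gives 28500 nM

In an ADME assay on Vero cells (Chlorocebus sabaeus) for cytotoxicity, read by resazurin assay, with a stated time of 72 h (on this read-out higher numbers stand for weaker inhibition and lower numbers for stronger inhibition), compound 2 holds the lower of the two numbers, and its gap to compound 1 lies beyond the usual scatter. Compound 3 (`O=C(CCN1CCN(c2ccc([N+](=O)[O-])cc2)CC1)c1ccc(C(F)(F)F)cc1`) differs from compound 2 as follows: nitro in place of fluoro on an aromatic carbon (nitro in place of fluoro on an aromatic carbon, para to a large group). Among the compounds with values here, no measured pair shows this change alone. Compound 1 also carries nitro and gives 79800 nM but differs from compound 2 elsewhere too. A modest rise in the number, meaning weaker inhibition and possibly within the scatter, is therefore expected (a 1.7-fold higher number from compound 2 to compound 3 (0.23 log units; within the scatter)). Compound 3 is estimated at 48000 nM (range 20000 nM to 110000 nM).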

Compound 3, half-maximal inhibitory concentration: 75700 nM
Beside the measured number, compound 3's estimate is 1.6-fold (0.20 log units) below it; low and high end bracket the measured number.
By their numbers in this assay, from the lowest: compound 2; then compounds 3 and 1 (each within the scatter of the next).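

In this assay, nitro in place of fluoro on an aromatic carbon gives a 2.7-fold higher number from compound 2 to compound 3 (0.42 log units; beyond the scatter), so this single change is enough to shift the number beyond the usual scatter, towards weaker inhibition. With nitro kept in place, trifluoromethyl in place of bromo gives a 1.1-fold lower number from compound 1 to compound 3 (0.02 log units; within the scatter), a step within the scatter. Nothing measured here offers a reason for either step.

On these data alone, whether an amine or a carboxylic acid at this position would move the number further remains open. So does whether the nitro step would keep its size with bromo on the other aromatic carbon.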